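From 2-(4-methylpiperazin-1-yl)ethyl to 2-hydroxyethyl

The source may hold more compounds than are shown below. What is called first, only, known or untested is meant among the compounds shown, and "the series" means these compounds.

In a functional assay on Raji cells (Homo sapiens) for antiproliferative activity, read by MTT assay, with a stated time of 48 h (a lower number here means a stronger inhibitor, a higher number a weaker inhibitor), compound 3 (`CN1CCN(CCn2c(N)c(-c3nc4ccccc4[nH]3)c3nc(C#N)c(C#N)nc32)CC1`) reads > 50000 nM as a limit of the assay, not a number. Compound 1 (`Cn1c(N)c(-c2nc3ccccc3[nH]2)c2nc(C#N)c(C#N)nc21`) reads > 50000 nM as a limit too. Going by the values given here, compound 2 (`CN(C)CCn1c(N)c(-c2nc3ccccc3[nH]2)c2nc(C#N)c(C#N)nc21`) gives 8320 nM as the one number. Compound 3 thus stands with compound 1 (the limit of > 50000 nM in this assay, at which 2 of the 3 values shown sit).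

Compound 4 (`N#Cc1nc2c(-c3nc4ccccc4[nH]3)c(N)n(CCO)c2nc1C#N`) has hydroxy in place of 4-methylpiperazin-1-yl on a saturated chain carbon, two bonds along the chain from an aromatic nitrogen.

Among the compounds with values here, three measured steps bear on this (an at least 6.0-fold lower number from compound 1 to compound 2 (0.77 log units; beyond the scatter) and an at least 6.0-fold higher number from compound 2 to compound 3 (0.77 log units; beyond the scatter) and a step that the two limits leave unreadable from compound 1 to compound 3). Only compound 2 gives a number (8320 nM). So only a modest move is expected. The step estimated here runs toward a lower number (an at least 1.4-fold lower number from compound 3 to compound 4 (0.15 log units; that floor lies within the scatter)). For compound 4 the expected value is 35000 nM with an estimated range from 10000 nM to 100000 nM in this assay as the read-out.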

Compound 4, half-maximal inhibitory concentration: 5520 nM
Beside the measured number, compound 4's estimate is 6.3-fold (0.80 log units) above it; measured number below the stated range.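

In this assay, a readable value at this position does not depend on a terminal amine, since hydroxy and dimethylamino cannot be told apart (a 1.5-fold lower number from compound 2 to compound 4 (0.18 log units; within the scatter)). The 2-hydroxyethyl group also separates compound 4 from the two compounds held at the limit (an at least 9.0-fold lower number from compound 3 to compound 4 (0.95 log units; beyond the scatter); an at least 9.0-fold lower number from compound 1 to compound 4 (0.95 log units; beyond the scatter)). The values of compound 1 and compound 3 remain limits of the assay, not numbers: the limit of > 50000 nM in this assay, at which 2 of the 4 values shown sit.

From the compounds shown here alone, whether a methoxy group or a longer chain ending in hydroxy keeps this level stays open. So does whether a morpholin-4-yl group behaves like 4-methylpiperazin-1-yl.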